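A few compounds are considered here, and "the series" means these few. Any claim that something is new, unique, unknown or untested is made for them only; others in the source may bear on it.

In a functional assay on DLD-1 cells (Homo sapiens) for cytotoxicity, read by MTT assay, with a stated time of 96 h (a lower number here means a stronger inhibitor, a higher number a weaker inhibitor), three compounds have been measured so far:

Compound 1 `O=Cc1cc(Br)c(O)c(O)c1Br` gives 31000 nM.
Compound 2 `O=Cc1cc(O)c(O)c(Br)c1Br` gives 30900 nM.
Compound 3 `CCCOCc1cc(O)c(O)c(Br)c1` gives 26300 nM.

Compound 2 stands second highest of these three numbers; its nearest neighbour is compound 1, which sits within the scatter, and compound 3, the furthest, also lies within the scatter, so the three values cannot be ranked against one another. Compound 4 `OCc1cc(O)c(O)c(Br)c1Br` has not yet been measured in this assay. It differs from compound 2 by hydroxymethyl in place of formyl on an aromatic carbon. For the measured compounds named here, no step between measured compounds exists to calibrate this change, and one expects only a small step in this assay, with no clear direction beyond the scatter. Compound 4 is accordingly expected to give 35000 nM, within a range from 15000 nM to 80000 nM, an expected step of a 1.1-fold higher number from compound 2 to compound 4 (0.05 log units; within the scatter).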

Compound 4, half-maximal inhibitory concentration: 18300 nM
For compound 4 the middle estimate is 1.9-fold (0.28 log units) above the measured one; the range from low to high includes it.
By their numbers in this assay, from the lowest: compounds 4, 3, 2 and 1 (each within the scatter of the next).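

In this assay, for the compounds shown here, hydroxymethyl in place of formyl on this aromatic carbon gives the first step that can be read at this position, a 1.7-fold lower number from compound 2 to compound 4 (0.23 log units; within the scatter), and it lies within the scatter. Compound 2 and compound 4 therefore cannot be ranked, although the entering group brings a hydrogen-bond donor that formyl lacks. Nothing measured here offers an explanation for this step. What the compounds shown leave open is whether a carboxylic acid, an amine or a longer chain on this carbon would give a step beyond the scatter.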